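The source may report more compounds than this note shows. Statements on the series, on what has been measured and on what is new or still open speak of the compounds shown alone.

Measured compounds:

Compound 1 `COc1ccc(-c2cc(-c3cccc(S(C)(=O)=O)c3)cnc2N)cn1` gives > 100 ug/mL in a physicochemical assay for solubility, read by nephelometry, measured as kinetic solubility, at pH 2 (a lower number here means a less soluble compound, a higher number a more soluble compound), a limit of the assay rather than a number.
Compound 2 `COc1ccc(-c2cc(-c3ccc(S(=O)(=O)N(C)C)cc3)cnc2N)cn1` gives > 100 ug/mL in this assay, again a limit.
Compound 3 `COc1ccc(-c2cc(-c3ccc(S(N)(=O)=O)cc3)cnc2N)cn1` gives > 100 ug/mL in this assay, also a limit.

Compound 3 therefore stands only at a limit in this assay, and so do the two other values shown; all three sit at the limit of > 100 ug/mL in this assay, at which 3 of the 3 values shown sit. For the measured compounds named here, the one measured step that changes a single place, amino in place of dimethylamino on a sulfonyl sulfur, is a step that the two limits leave unreadable from compound 2 to compound 3, and its size cannot be read because both ends are limits. Going by the values given here, no step has a readable size, so there is no measured direction to carry forward.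

Compound 4 `COc1ccc(-c2cc(-c3ccc(C(F)(F)F)cc3)cnc2N)cn1` differs from compound 3 by trifluoromethyl in place of sulfamoyl on an aromatic carbon. Among the compounds with values here, none of the measured steps involves a change of this kind, so the expectation rests on the structural change alone and is held loosely.

The step from compound 3 to compound 4 in this assay is expected to be an at least 2.0-fold lower number from compound 3 to compound 4 (0.30 log units; that floor lies within the scatter), towards a less soluble compound, with the possibility that the assay again reports only a limit. For compound 4 the estimate in this assay is 50 ug/mL, with a range of 10 ug/mL to 100 ug/mL.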

Compound 4, solubility: > 100 ug/mL
Compound 4: a limit, no number; the forecaster's own chance of this, stated with the estimate: 40%; middle value at least 2.0-fold (0.30 log units) away from the limit.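

In this assay compound 4 gives > 100 ug/mL, a limit of the assay and not a number. No new step can be read from compound 2 or compound 3 to compound 4 because both ends of each are limits: the limit of > 100 ug/mL in this assay, at which 4 of the 4 values shown sit.

Left open are the size and direction of any difference among compound 1, compound 2, compound 3 and compound 4 in this assay.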